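Swapping Furan-3-yl for 1H-pyrrol-3-yl

The source may report more compounds than this note shows. Statements on the series, on what has been measured and on what is new or still open speak of the compounds shown alone.

In a functional assay on A549 cells (Homo sapiens), read by sulforhodamine B assay, with a stated time of 5 days (a higher number here means a weaker inhibitor of growth, a lower number a stronger inhibitor of growth), compound 3 `OC[C@H]1O[C@@H](n2cc(F)c3c(-c4ccoc4)ncnc32)[C@H](O)[C@@H]1O` gives 60 nM and lies within the scatter of compound 1 `OC[C@H]1O[C@@H](n2cc(F)c3c(-c4ccco4)ncnc32)[C@H](O)[C@@H]1O` at 110 nM while compound 2 `OC[C@H]1O[C@@H](n2cc(F)c3c(-c4nccs4)ncnc32)[C@H](O)[C@@H]1O` gives a clearly higher 900 nM as the outlier. Compound 4 `OC[C@H]1O[C@@H](n2cc(F)c3c(-c4cc[nH]c4)ncnc32)[C@H](O)[C@@H]1O` carries 1H-pyrrol-3-yl in place of furan-3-yl on an aromatic carbon. Swapping furan-2-yl for furan-3-yl gave only a 1.8-fold lower number from compound 1 to compound 3 (0.26 log units; within the scatter) whereas replacing 1,3-thiazol-2-yl with furan-3-yl gave a 15-fold lower number from compound 2 to compound 3 (1.18 log units; beyond the scatter) and shows that a ring swap can count. Within the data shown here, no measured compound carries 1H-pyrrol-3-yl, so the range stays wide, but no step beyond the scatter is expected in this assay for this close swap. The expected change is a 1.5-fold higher number from compound 3 to compound 4 (0.18 log units; within the scatter) and points slightly upward. Compound 4 is estimated at 90 nM with an expected range from 25 nM to 350 nM in all.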

Compound 4, concentration for 50% growth inhibition: 130 nM
The estimate for compound 4 lay 1.4-fold (0.16 log units) below the measured number, and the stated range covers the measured number.
By their numbers in this assay, from the lowest: compounds 3, 1 and 4 (each within the scatter of the next, the first and the last beyond it); then compound 2.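

In this assay the change from furan-3-yl to 1H-pyrrol-3-yl, which brings in a hydrogen-bond donor, gives a 2.2-fold higher number from compound 3 to compound 4 (0.34 log units; beyond the scatter) and so shows that this position can register the swap of a single ring atom. Compound 2 still stands apart, with a 6.9-fold lower number from compound 2 to compound 4 (0.84 log units; beyond the scatter) set against a 1.2-fold higher number from compound 1 to compound 4 (0.07 log units; within the scatter) and no such gap among the other rings. Nothing measured here explains the shift. As far as these compounds go, how a phenyl ring or an amine on this aromatic carbon would compare stays open, as does whether a methyl group on the pyrrole nitrogen would change the number.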